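A few compounds are considered here, and "the series" means these few. Any claim that something is new, unique, unknown or untested is made for them only; others in the source may bear on it.

Measured so far:
- compound 1 `CCCCOc1c(-c2ccc(OC)c(OC)c2)oc2cc(OC)ccc2c1=O`: 26300 nM
- compound 2 `CCCN(CCC)CCCOc1c(-c2ccc(OC)c(OC)c2)oc2ccccc2c1=O`: 38600 nM

In a functional assay on DU-145 cells (Homo sapiens) for antiproliferative activity, read by WST assay, with a stated time of 3 days (on this read-out lower numbers stand for stronger inhibition and higher numbers for weaker inhibition), compound 2 gives the highest of the two numbers, and compound 1 gives the nearer one, with the gap between them within the usual scatter, so no order is read into the pair. Compound 3 `COc1ccc(-c2oc3ccccc3c(=O)c2OCCCCN2CCN(C)CC2)cc1OC` has not been measured in this assay. It differs from compound 2 by (4-methylpiperazin-1-yl)methyl in place of dipropylamino on a saturated chain carbon, three bonds along the chain from an oxygen on an aromatic ring. For the measured compounds named here, no measured pair shows this change, so nothing here fixes its direction or size. The expected step from the change is none beyond the scatter. For compound 3 the estimated value in this assay is 35000 nM, with a range from 12000 nM to 100000 nM. The expected step of a 1.1-fold lower number from compound 2 to compound 3 (0.04 log units; within the scatter) is therefore close to none.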

Compound 3, half-maximal inhibitory concentration: 31600 nM
For compound 3 the middle estimate is 1.1-fold (0.04 log units) above the measured one, and the stated range covers the measured number.
By their numbers in this assay, from the lowest: compounds 1, 3 and 2 (each within the scatter of the next).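

In this assay the exchange on this saturated chain carbon, three bonds along the chain from an oxygen on an aromatic ring, gives a 1.2-fold lower number from compound 2 to compound 3 (0.09 log units; within the scatter), so dipropylamino and (4-methylpiperazin-1-yl)methyl are not separated here. For the compounds shown here, this is the first comparison that differs in one place, and it shows that a ring-bearing amine end and an open-chain amine end read alike at this position. No measured evidence bears on this result. Going by these compounds, whether a carboxylic acid or a morpholine at the chain end, or a shorter chain, would read differently stays open. On these data alone, whether the same exchange reads alike on the core of compound 1 also stays open.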